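Replacing the group on the carbonyl carbon

A few compounds are considered here, and "the series" means these few. Any claim that something is new, unique, unknown or untested is made for them only; others in the source may bear on it.

Among the compounds with values here, in an ADME assay on microsomes from liver (Homo sapiens) for metabolic stability, read by LC-MS, with a stated time of 30 min, tested at 1 uM (a lower number here means that less of the compound is left, a higher number that more of the compound is left), compound 2 `O=C(NCc1ccc(S(=O)(=O)N2CCCCC2)cc1)c1ccc2nc[nH]c2c1` gives 53%, the higher of the two numbers so far but within the scatter of compound 1 `O=C(NCc1ccc(S(=O)(=O)N2CCCCC2)cc1)c1cc2cnccc2o1`, which gives 46%. The next structure is compound 3 `O=C(NCc1ccc(S(=O)(=O)N2CCCCC2)cc1)c1cc2cccnc2s1`, which keeps the rest of compound 2 and changes the group on a carbonyl carbon whose other neighbours are: amide-type nitrogen. The change is a group of 9 heavy atoms (7 carbon, 1 nitrogen, 1 sulfur; one five-membered aromatic ring with 1 hetero atom, one six-membered aromatic ring with 1 hetero atom) in place of a group of 9 heavy atoms (7 carbon, 2 nitrogen; one five-membered aromatic ring with 2 hetero atoms, one six-membered aromatic ring of carbon only), on a carbonyl carbon.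

Within the data shown here, only one measured step bears on this change: a number 7 percentage points higher from compound 1 to compound 2 (within the scatter). It too exchanges one group of 9 heavy atoms for another at the same place. A single step is thin evidence, so the range is kept wide. The expected step is a number 8 percentage points lower from compound 2 to compound 3 (within the scatter), and no change beyond the scatter is expected. In this assay, the estimate for compound 3 is 45%, with an expected range from 27% to 63%.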

Compound 3, percent of the compound remaining: "below limit of detection" (no number reported)
For compound 3 the study gives words and no number, and the estimate cannot be compared.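

Within the data shown here, compound 3 is reported in this assay in words and without a number, so no step from compound 2 to compound 3 can be read. The compounds shown leave open how far the sulfur-containing group on the carbonyl carbon shifts the percent remaining. Nothing shown accounts for this result.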